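The compounds below may be only part of what the source reports. "The series", "measured", "known", "first", "only" and "open" are said of these compounds alone.

Compound 1 `Cc1cc(C)c(NC(=O)N(Cc2cccc(-n3cccc3)c2)C2CCCCCC2)c(C)c1`: 20 nM
Compound 2 `Cc1cc(C)c(NC(=O)N(Cc2ccc(-c3cnn(C)c3)cc2)C2CCCCCC2)c(C)c1`: 47 nM

Among the measured compounds shown here, in an assay on microsomes from intestine for inhibition of acyl-CoA:cholesterol acyltransferase (Oryctolagus cuniculus) (on this read-out higher numbers stand for weaker inhibition and lower numbers for stronger inhibition), compound 1 gives 20 nM, the lower of the two numbers so far. Compound 2 gives 47 nM, and this gap lies beyond the usual scatter. Compound 3 `Cc1cc(C)c(NC(=O)N(Cc2cccc(-c3cnn(C)c3)c2)C2CCCCCC2)c(C)c1` is not yet measured; it differs from compound 1 by 1-methyl-1H-pyrazol-4-yl in place of 1H-pyrrol-1-yl on an aromatic carbon. For the measured compounds named here, no measured pair shows this exact exchange. A modest step toward weaker inhibition is expected, a 1.8-fold higher number from compound 1 to compound 3 (0.24 log units; within the scatter), since compound 2 also carries the 1-methyl-1H-pyrazol-4-yl group and gives 47 nM. Compound 3 is estimated at 35 nM, with a range from 15 nM to 80 nM.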

Compound 3, half-maximal inhibitory concentration: 44 nM
Estimate against measurement, compound 3: 1.3-fold (0.10 log units) below, and the stated range covers the measured number.
By their numbers in this assay, from the lowest: compound 1; then compounds 3 and 2 (each within the scatter of the next).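

In this assay, 1-methyl-1H-pyrazol-4-yl in place of 1H-pyrrol-1-yl on this aromatic carbon now has a direct reading: a 2.2-fold higher number from compound 1 to compound 3 (0.34 log units; beyond the scatter), a modest step. Compound 3 at 44 nM and compound 2 at 47 nM, which carries the same group elsewhere on the ring, lie within the scatter of each other. Nothing on hand accounts for the step. Open, on these data alone, is how an aminomethyl group or a carboxylic acid at this carbon would read, and how 1H-pyrrol-1-yl would read at the ring place held in compound 2.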